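Adding trifluoromethoxy to compound 1

This account rests on a few compounds, and the source may have more. Where it says the series, first, only, none or still open, it means among the compounds named here.

Compound 1 `Cn1nc(-c2ccccc2)c2c1OC(N)=C(C#N)C2c1ccccc1`: > 10000 nM
Compound 2 `Cn1nc(-c2ccccc2)c2c1OC(N)=C(C#N)C2c1cc(F)cc(F)c1`: 6600 nM

In a functional assay on NCI-H2122 cells (Homo sapiens) for inhibition, read by microscopy, with a stated time of 10 days (a higher number here means a weaker inhibitor, a lower number a stronger inhibitor), compound 1 gives > 10000 nM, which is a limit of the assay and not a number. All that is known of compound 1 is the limit of > 10000 nM in this assay, at which 1 of the 2 values shown sits. Swapping phenyl for 3,5-difluorophenyl on a saturated ring carbon gives an at least 1.5-fold lower number from compound 1 to compound 2 (0.18 log units; that floor lies within the scatter).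

Compound 3 `Cn1nc(-c2ccccc2)c2c1OC(N)=C(C#N)C2c1ccc(OC(F)(F)F)cc1` keeps the core of compound 1 and carries trifluoromethoxy in place of hydrogen on an aromatic carbon, para to a large group: trifluoromethoxy in place of hydrogen on an aromatic carbon. Among the measured compounds shown here, only one measured step is available as a guide, and compound 2 carries different groups from compound 3, so that step bears on this change only loosely. In this assay a small move towards a lower number is therefore expected, perhaps none beyond the scatter, and compound 3 could also end up reported only as a limit. The expected change is an at least 1.2-fold lower number from compound 1 to compound 3 (0.09 log units; that floor lies within the scatter). For compound 3 the estimate is 8000 nM, with an expected range of 3000 nM to 20000 nM.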

Compound 3, half-maximal inhibitory concentration: 5500 nM
Estimate against measurement, compound 3: 1.5-fold (0.16 log units) above; the measured number falls inside the stated range.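

Among the compounds shown here, with trifluoromethoxy in place of hydrogen on an aromatic carbon, para to a large group, a single added group at this position now gives a measured number in this assay, something the earlier compounds could not show. The change amounts to an at least 1.8-fold lower number from compound 1 to compound 3 (0.25 log units; that floor lies within the scatter), so the printed floor alone does not establish a real gain for this change, although a larger true step remains possible. The true size of the step cannot be read, because compound 1 has only a limit and not a number as its starting point: the limit of > 10000 nM in this assay, at which 1 of the 3 values shown sits.

Still open, from the compounds shown here alone, is whether this response belongs to trifluoromethoxy itself or whether other groups at the same position, such as a methoxy group, a chlorine atom, an amine or a carboxylic acid, would give similar or quite different numbers. Also open, going by these compounds, is whether trifluoromethoxy would give a similar number on another carbon of the same aromatic ring, and a value for a compound without the group that is a number rather than a limit would be needed to fix the size of this step.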